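Halogen exchange on the aryl ring: compound 3 to compound 4

The source may report more compounds than this note shows. Statements on the series, on what has been measured and on what is new or still open speak of the compounds shown alone.

Among the compounds with values here, compound 3 `O=C1NC(=S)/C(=C/c2ccccc2Cl)S1` gives 10.6% in a functional assay on NCI-H292 cells (Homo sapiens) for cytotoxicity, read by MTT assay, with a stated time of 72 h, tested at 1.25 ug/mL (on this read-out higher numbers stand for more inhibition of growth at the one concentration tested and lower numbers for less inhibition of growth), the second highest of the three numbers so far. Compound 1 `O=C1NC(=S)/C(=C/c2ccccc2Br)S1` gives 13.3% and compound 2 `O=C1NC(=S)/C(=C/c2cccc(Cl)c2)S1` gives 3.35% in this assay; all three lie within the scatter of one another, so no order among them is established. Within the data shown here, the one measured step that exchanges a halogen on an aromatic carbon is a number 2.7 percentage points lower from compound 1 to compound 3 (within the scatter), within the scatter. Compound 4 `O=C1NC(=S)/C(=C/c2ccccc2F)S1` differs from compound 3 by fluoro in place of chloro on an aromatic carbon. Since the earlier halogen exchange gave a number 2.7 percentage points lower from compound 1 to compound 3 (within the scatter), a further exchange is expected to stay within the scatter, with no direction beyond it. Compound 4 is therefore expected to give about 9%, ranging from 0% to 20%. The expected step is a number 1.6 percentage points lower from compound 3 to compound 4 (within the scatter).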

Compound 4, percent growth inhibition at one concentration: 4.29%
The estimate for compound 4 lay 4.7 percentage points above the measured number, and the stated range covers the measured number.
By their numbers in this assay, from the lowest: compounds 2, 4, 3 and 1 (each within the scatter of the next).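

Fluoro brings a third halogen to this aromatic carbon, ortho to a group of 8 heavy atoms: in this assay the step is a number 6.3 percentage points lower from compound 3 to compound 4 (within the scatter), and the wider exchange is a number 9 percentage points lower from compound 1 to compound 4 (within the scatter). Even the exchange spanning bromo to fluoro therefore does not separate these compounds, so bromo, chloro and fluoro cannot be told apart at this place.

As far as these compounds go, whether a group other than a halogen, such as an amine or a carboxylic acid, would move the number here beyond the scatter remains open. Nothing available bears on the reason for this result.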